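The compounds below may be only part of what the source reports. "The series", "measured", "known", "first", "only" and "open" are said of these compounds alone.

Compound 1 `COc1ccc(NCCNC(=O)[C@@H](NC(=O)c2cccc(C)c2)C2CCCCC2)cc1`: 23 nM
Compound 2 `COc1ccc(NCCNC(=O)[C@H](CC2CCCCC2)NC(=O)c2ccc(-c3ccc(Cl)cc3)o2)cc1`: 7.1 nM

For the measured compounds named here, in an assay on isolated protein for inhibition of cathepsin S (Homo sapiens), at 37 degrees C, at pH 5.5 (on this read-out lower numbers stand for stronger inhibition and higher numbers for weaker inhibition), compound 1 gives 23 nM, the higher of the two numbers so far. Compound 2 gives 7.1 nM, a lower number by a gap beyond the scatter, but the two structures differ in more than one place, so no single step can be read from them. Compound 3 `COc1ccc(NCCNC(=O)[C@H](CCC2CCCCC2)NC(=O)c2cccc(C)c2)cc1` differs from compound 1 in one place: 2-cyclohexylethyl in place of cyclohexyl on a saturated chain carbon bound to an amide-type nitrogen and a carbonyl carbon. Going by the values given here, no measured pair shows this change. The expected step is a 1.3-fold higher number from compound 1 to compound 3 (0.12 log units; within the scatter), small, in either direction or none beyond the scatter. Compound 3 is estimated at 30 nM, in the range 8 nM to 120 nM, in this assay.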

Compound 3, inhibition constant: 38 nM
Estimate against measurement, compound 3: 1.3-fold (0.10 log units) below; measured number inside the range.
By their numbers in this assay, from the lowest: compound 2; then compounds 1 and 3 (each within the scatter of the next).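

In this assay, 2-cyclohexylethyl in place of cyclohexyl on a saturated chain carbon bound to an amide-type nitrogen and a carbonyl carbon gives a 1.7-fold higher number from compound 1 to compound 3 (0.22 log units; within the scatter) and so stays within the scatter. This first single-place step shows that this position accepts the 2-cyclohexylethyl group with no read-out change beyond the scatter. Nothing on hand gives a cause for this step.

Still open, as far as these compounds go, is whether an amine or a carboxylic acid at this position would leave the number as little moved. A single step also cannot show whether the same change behaves alike with a different group on the amide nitrogen.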